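Chromone styryl series: effect of an added methoxy

A few compounds are considered here, and "the series" means these few. Any claim that something is new, unique, unknown or untested is made for them only; others in the source may bear on it.

Measured so far in a functional assay on HeLa cells (Homo sapiens) for antiproliferative activity, read by MTT assay, with a stated time of 12 h; on this read-out lower numbers stand for stronger inhibition and higher numbers for weaker inhibition:
- compound 1, `COc1ccc2c(=O)cc(/C=C/c3ccc(OC(F)(F)F)cc3)oc2c1`, 9900 nM
- compound 2, `COc1cc(OC)c2c(=O)cc(/C=C/c3ccccc3)oc2c1`, 10100 nM
- compound 3, `COc1ccc(/C=C/c2cc(=O)c3c(OC)cc(OC)cc3o2)cc1`, 17800 nM

The three measured compounds give half-maximal inhibitory concentrations that all lie close together in this assay. Compound 2 and compound 3 differ in one place: methoxy in place of hydrogen on an aromatic carbon. The step is a 1.8-fold higher number from compound 2 to compound 3 (0.25 log units; within the scatter), so no effect of that change can be claimed from this pair. Compound 1 and compound 2 differ in their cores, and the difference between the two cores is not broken down here.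

Compound 4, `COc1ccc2c(=O)cc(/C=C/c3ccc(OC(F)(F)F)cc3)oc2c1OC`, has not been measured. It differs from compound 1 in one place: methoxy in place of hydrogen on an aromatic carbon. This is the same kind of change as that from compound 2 to compound 3, but not the same: in compound 3 the entering group sits para to a large group on the ring that carries the vinyl link, whereas in compound 4 it sits on the fused core, ortho to a fused ring, ortho to a methoxy group and meta to a fused ring.

Within the data shown here, for compound 4 in this assay the step from compound 1 is expected to be a 1.3-fold higher number from compound 1 to compound 4 (0.12 log units; within the scatter), resting on the only measured example of this kind of change, which gave a 1.8-fold higher number from compound 2 to compound 3 (0.25 log units; within the scatter), and on the fact that the new group enters at a different place, so the transfer is uncertain. Compound 4 is therefore estimated at 13000 nM, with a plausible range from 5000 nM to 40000 nM.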

Compound 4, half-maximal inhibitory concentration: 4900 nM
The estimate for compound 4 lay 2.7-fold (0.42 log units) above the measured number; the whole stated range lies above it.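

In this assay, methoxy in place of hydrogen on the core of compound 1 gives a 2.0-fold lower number from compound 1 to compound 4 (0.31 log units; beyond the scatter), a modest step. Set beside the earlier case, the change does not carry from one core to the other with a single size or direction: the same change on two cores in this assay, a 1.8-fold higher number (0.25 log units; within the scatter) from compound 2 to compound 3 and a 2.0-fold lower number (0.31 log units; beyond the scatter) from compound 1 to compound 4, 3.6-fold (0.55 log units) apart, beyond the scatter of two such steps

This shows that a step read on one of these cores is a poor guide to the step on the other, but it does not show why, and it gives no rule for the series. Among these compounds, each core contributes only one pair, the earlier step is itself within the scatter, and the methoxy enters at a different place in each pair. In compound 4 it stands on the fused core, ortho to a fused ring, ortho to a methoxy group and meta to a fused ring, so the role of the core cannot be separated from that of the place.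

Still open, as far as these compounds go, is whether the lower number of compound 4 depends on methoxy itself or would also appear with a hydroxyl, an ethoxy or an amine at that place. Also open, from the compounds shown here alone, is whether the step would hold if the trifluoromethoxy group on the styryl ring were replaced by hydrogen or by a simple methoxy.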